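Anilino for Hydroxy: Expected Growth Inhibition of Compound 4

This account rests on a few compounds, and the source may have more. Where it says the series, first, only, none or still open, it means among the compounds named here.

Compound 1 `CC(=O)SCCC(CCCCC(=O)O)SC(C)=O`: 6.04%
Compound 2 `O=C(O)CCCCC(CCSC(=O)c1ccccc1)SC(=O)c1ccccc1`: "not active" (no number reported)
Compound 3 `CC(=O)SCCC(CCCCC(=O)Nc1ccccc1)SC(C)=O`: 14.2%

In a functional assay on NCI-H460 cells (Homo sapiens) for inhibition, read by MTT assay, with a stated time of 24 h, tested at 10 ug/mL (a higher number here means more inhibition of growth at the concentration tested, a lower number less inhibition of growth), compound 1 gives 6.04% and compound 3 gives 14.2%. Compound 2 is reported in this assay only as "not active" (no number reported), without a number. The two measured pairs share one change: anilino in place of hydroxy on a carbonyl carbon, and the step it made, a number 8.2 percentage points higher from compound 1 to compound 3 (within the scatter), is small. The same kind of change, at the same place, leads from compound 2 to the unmeasured compound 4 `O=C(CCCCC(CCSC(=O)c1ccccc1)SC(=O)c1ccccc1)Nc1ccccc1`: anilino in place of hydroxy on a carbonyl carbon. How the core of compound 2 differs from the core of compound 1 is not broken down here. Since the change from compound 1 to compound 3 stayed within the scatter, the step from compound 2 to compound 4 is expected to be small as well, and compound 2 gives no number to build on. Compound 4 is therefore estimated at 10% in this assay, most likely between 0% and 25%, with a real chance that it too is reported only as not active.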

Compound 4, percent growth inhibition at one concentration: 11.4%
The estimate for compound 4 lay 1.4 percentage points below the measured number; the measured number falls inside the stated range.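

Compound 2 is reported only as "not active" in this assay, and the step from it to compound 4 cannot be read. The compounds shown leave open how far anilino in place of hydroxy moves growth inhibition on the core of compound 2. No measured evidence here bears on the result for compound 4.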